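Swapping phenyl for methyl on the pyrrole core

This account rests on a few compounds, and the source may have more. Where it says the series, first, only, none or still open, it means among the compounds named here.

Measured compounds in an ADME assay on HMEC-1 cells (Homo sapiens) for cytotoxicity, read by MTT assay; a higher number here means a weaker inhibitor, a lower number a stronger inhibitor:
compound 1 `CCN(CC)Cc1cc(-c2ccccc2)n(Nc2ccnc3cc(Cl)ccc23)c1C` gives 16700 nM
compound 2 `Cc1c(CNC[C@@H]2CCCN3CCCC[C@H]23)cc(-c2ccccc2)n1Nc1ccnc2cc(Cl)ccc12` gives 13500 nM
compound 3 `Cc1c(CN2CCCC2)cc(-c2ccccc2)n1Nc1ccnc2cc(Cl)ccc12` gives 12900 nM

The three compounds share a core and differ only in the amine carried on the saturated chain carbon. All three values lie within the scatter of one another: the step of a 1.2-fold lower number from compound 1 to compound 2 (0.09 log units; within the scatter) and the step of a 1.0-fold lower number from compound 2 to compound 3 (0.02 log units; within the scatter) are both small, and compound 2 sits among them without any separation that the scatter would support.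

Compound 4 `Cc1cc(CNC[C@@H]2CCCN3CCCC[C@H]23)c(C)n1Nc1ccnc2cc(Cl)ccc12` departs from compound 2 at a different place: methyl in place of phenyl on an aromatic carbon. Among the compounds with values here, none of the measured steps touches this position; each of them changes the amine, not the ring substituents. There is therefore no direct guide for this change, and the amine changes themselves show that this series tolerates substitution without a shift in this assay beyond the scatter.

It is expected that compound 4 shows no step beyond the scatter, no change at the digits printed from compound 2 to compound 4 (within the scatter). The estimate for compound 4 is 13500 nM, with a range from 6000 nM to 30000 nM.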

Compound 4, half-maximal inhibitory concentration: 5400 nM
Beside the measured number, compound 4's estimate is 2.5-fold (0.40 log units) above it, outside the stated range (below it).
By their numbers in this assay, from the lowest: compound 4; then compounds 3, 2 and 1 (each within the scatter of the next).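

In this assay, methyl in place of phenyl gives a 2.5-fold lower number from compound 2 to compound 4 (0.40 log units; beyond the scatter), a modest step but the only one in this set that lies beyond the scatter. The amine changes among compound 1, compound 2 and compound 3 had left the number within the scatter, whereas this aromatic carbon, next to the ring nitrogen, is a place where a change of substituent does register. The data shown offer no measurement that would explain this shift.

This single pair leaves open whether the step follows the loss of the aromatic ring or the drop in group size, and cyclohexyl or ethyl at this position could separate the two. From the compounds shown here alone, it also remains open whether the same swap lowers the number when the amine is the pyrrolidin-1-yl group of compound 3.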